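The source may report more compounds than this note shows. Statements on the series, on what has been measured and on what is new or still open speak of the compounds shown alone.

Of the compounds shown here, three sharing one core have been measured in an ADME assay on the whole organism (plasma, Rattus norvegicus) for protein binding, using cassette dosing, at a dose of 1 mg/kg; on this read-out higher numbers stand for a larger free fraction and lower numbers for a smaller free fraction. Compound 1 `C[C@@H](Cn1c(=O)[nH]/c(=N\c2ccc(Oc3nccs3)cc2)n(Cc2ccc(Cl)cc2)c1=O)C(=O)O` gives 0.006. Compound 2 `C[C@@H](Cn1c(=O)[nH]/c(=N\c2ccc(Oc3cncc(F)c3)cc2)n(Cc2ccc(Cl)cc2)c1=O)C(=O)O` gives 0.02. Compound 3 `C[C@@H](Cn1c(=O)[nH]/c(=N\c2ccc(OC3CCC3)cc2)n(Cc2ccc(Cl)cc2)c1=O)C(=O)O` gives 0.015, the second highest of the three numbers; it stands nearest to compound 2, within the scatter, and furthest from compound 1, beyond it.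

The steps among them are a 3.3-fold higher number from compound 1 to compound 2 (0.52 log units; beyond the scatter) and a 2.5-fold higher number from compound 1 to compound 3 (0.40 log units; beyond the scatter), both modest and beyond the scatter, while a 1.3-fold lower number from compound 2 to compound 3 (0.12 log units; within the scatter) is within the scatter.

Compound 4 `C[C@@H](Cn1c(=O)[nH]/c(=N\c2ccc(Oc3ccc(F)cn3)cc2)n(Cc2ccc(Cl)cc2)c1=O)C(=O)O` has not yet been measured. It differs from compound 3 in one place: 5-fluoropyridin-2-yl in place of cyclobutyl on an oxygen on an aromatic ring. Among the compounds with values here, the step that bears most directly on this change is the one from compound 2 to compound 3, where a six-membered aromatic ring with one nitrogen and a fluorine was exchanged for the cyclobutyl group and the number moved only within the scatter. The group entering in compound 4 is again a fluorinated six-membered aromatic ring with one nitrogen, so a step close to the scatter is expected in this assay, leaning slightly upward toward the value of compound 2. Compound 4 is therefore estimated at 0.018, with a range from 0.008 to 0.04, which would mean a step of a 1.2-fold higher number from compound 3 to compound 4 (0.08 log units; within the scatter).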

Compound 4, unbound fraction: 0.011
Compound 4: middle estimate off by 1.6-fold (0.21 log units), on the high side; the range from low to high includes it.
By their numbers in this assay, from the lowest: compounds 1, 4, 3 and 2 (each within the scatter of the next, the first and the last beyond it).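

On the oxygen on the aromatic ring, 5-fluoropyridin-2-yl in place of cyclobutyl, an exchange that brings in more heavy atoms and a hydrogen-bond acceptor, gives in this assay only a 1.4-fold lower number from compound 3 to compound 4 (0.13 log units; within the scatter), so this exchange does not separate the two compounds on this read-out. The two fluoropyridinyl groups are not separated either, with a 1.8-fold lower number from compound 2 to compound 4 (0.26 log units; within the scatter), and the thiazolyl comparison gives a 1.8-fold higher number from compound 1 to compound 4 (0.26 log units; within the scatter), so compound 4 stands within the scatter of all three earlier compounds, even though compound 1 is separated beyond the scatter from both compound 2 and compound 3. Nothing given here accounts for the size of these steps.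

The compounds shown vary only the group on this oxygen, so they leave open how the free fraction would respond to a change at any other place on the shared core. They also leave open whether a group of another kind on this oxygen, such as an amine or a longer alkyl chain, would give a step beyond the scatter from compound 3.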